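The source may report more compounds than this note shows. Statements on the series, on what has been measured and on what is new or still open speak of the compounds shown alone.

Of the compounds shown here, three built on one shared core have so far been read in an ADME assay on a cell-free system (plasma, Homo sapiens) for metabolic stability (on this read-out higher numbers stand for a longer-lived compound and lower numbers for a shorter-lived compound), and they spread widely. Compound 1 (`COC(=O)N1C(=O)[C@@H](C)[C@@H]2[C@@H]1CCN2C(=O)OCc1ccccc1`) gives 0.833 h in this read-out. Compound 2 (`C[C@@H]1C(=O)N(S(C)(=O)=O)[C@H]2CCN(C(=O)OCc3ccccc3)[C@H]12`) gives < 0.0834 h as a limit of the assay and not as a number. Compound 3 (`C[C@@H]1C(=O)N(c2ccc([N+](=O)[O-])cc2[N+](=O)[O-])[C@H]2CCN(C(=O)OCc3ccccc3)[C@H]12`) gives > 24 h as a limit of the assay and not as a number. It stands at the limit of > 24 h in this assay, at which 1 of the 3 values shown sits, and so has no exact value to start from.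

Compound 4 (`C[C@@H]1C(=O)N(c2ccc([N+](=O)[O-])cc2)[C@H]2CCN(C(=O)OCc3ccccc3)[C@H]12`) has hydrogen in place of nitro on an aromatic carbon of compound 3, at the place ortho to a large group and meta to a nitro group: hydrogen in place of nitro on an aromatic carbon is the whole difference. Within the data shown here, the only measured step is an at least 9.9-fold lower number from compound 1 to compound 2 (0.99 log units; beyond the scatter) and it lies beyond the scatter, but it swaps methoxycarbonyl for methylsulfonyl on the amide-type nitrogen and removes no nitro group. It shows that this nitrogen's substituent can matter, yet it gives no size for the present change. The expectation therefore rests on compound 3 and its > 24 h alone. The expected change is a number no higher from compound 3 to compound 4 (the limit leaves the size open) and it is not expected to exceed the scatter. The estimate for compound 4 is 24 h with an expected range from 8 h to 72 h and a fair chance of another limit.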

Compound 4, half-life: 40 h
Beside the measured number, compound 4's estimate is 1.7-fold (0.22 log units) below it; measured number inside the range.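

In this assay compound 4 gives an exact number, 40 h, so a nitrophenyl group on the amide-type nitrogen in a ring now has a value that can be compared with the other groups at that nitrogen. With 4-nitrophenyl in place of methoxycarbonyl there is a 48-fold higher number from compound 1 to compound 4 (1.68 log units; beyond the scatter), and with 4-nitrophenyl in place of methylsulfonyl there is an at least 470-fold higher number from compound 2 to compound 4 (2.68 log units; beyond the scatter), so both steps are large and the choice of group on this nitrogen is tied to a wide span of half-lives in these compounds. The step from compound 3 to compound 4 cannot be read, so the removal of the nitro group has no measured size, because compound 3 holds only a limit: the limit of > 24 h in this assay, at which 1 of the 4 values shown sits.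

The compounds shown leave open how the number of compound 4 would respond to an amine or a methoxy group on the aromatic carbon that is ortho to a large group and meta to a nitro group. They also leave open how a plain phenyl ring or an acetyl group on the amide-type nitrogen would read, and why the groups at that nitrogen differ so widely.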